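Same Benzyl Swap on Two Different Cores

The source may hold more compounds than are shown below. What is called first, only, known or untested is meant among the compounds shown, and "the series" means these compounds.

Compound 3 `O=C1/C(=C/c2ccccc2F)CN(Cc2cn(Cc3ccc(F)cc3)nn2)C/C1=C\c1ccccc1F` gives 8700 nM in a functional assay on DU-145 cells (Homo sapiens) for cytotoxicity, read by MTT assay, with a stated time of 24 h; a lower number here means a stronger inhibitor, a higher number a weaker inhibitor. Compound 1 `O=C1/C(=C/c2ccccc2F)CN(Cc2cn(Cc3cccc(Cl)c3)nn2)C/C1=C\c1ccccc1F` gives 4300 nM in this assay. The change between them, (3-chlorophenyl in place of 4-fluorophenyl on a saturated chain carbon bound to an aromatic nitrogen), brought a 2.0-fold lower number from compound 3 to compound 1 (0.31 log units; beyond the scatter). Compound 2 `O=C1/C(=C/c2ccccc2F)CN(C(=S)SCc2cn(Cc3ccc(F)cc3)nn2)C/C1=C\c1ccccc1F` gives 35700 nM in this assay, the highest of the three numbers; the difference between the cores of compound 2 and compound 3 is not broken down here. Compound 4 `O=C1/C(=C/c2ccccc2F)CN(C(=S)SCc2cn(Cc3cccc(Cl)c3)nn2)C/C1=C\c1ccccc1F` carries the same change as compound 1 relative to compound 3, namely (3-chlorophenyl in place of 4-fluorophenyl on a saturated chain carbon bound to an aromatic nitrogen), at a place described in identical words. Because the earlier step was a 2.0-fold lower number from compound 3 to compound 1 (0.31 log units; beyond the scatter), compound 4 is expected to show a step of about a 2.0-fold lower number from compound 2 to compound 4 (0.30 log units; within the scatter) in this assay, with its only support being that single earlier pair. Compound 4 is therefore estimated at 18000 nM, expected to fall between 9000 nM and 40000 nM.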

Compound 4, half-maximal inhibitory concentration: > 80000 nM
Compound 4: no number, only a limit (the forecaster's own chance of this, stated with the estimate: 5%); middle value at least 4.4-fold (0.64 log units) away from the limit.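

In this assay compound 4 gives > 80000 nM, which is a limit of the assay and not a number. On the core of compound 2, 3-chlorophenyl in place of 4-fluorophenyl brought an at least 2.2-fold higher number from compound 2 to compound 4 (0.35 log units; beyond the scatter), so the change did not carry over from one core to the other: the same change on two cores in this assay, a 2.0-fold lower number (0.31 log units; beyond the scatter) from compound 3 to compound 1 and an at least 2.2-fold higher number (0.35 log units; beyond the scatter) from compound 2 to compound 4, at least 4.5-fold (0.65 log units) apart, beyond the scatter of two such steps This rests on a single pair per core, so it shows that the step failed to transfer here but neither gives a rule for the series nor explains the reversal.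

The compounds shown leave open how the two cores would compare with other groups at this place, such as an unsubstituted benzyl or a longer alkyl chain. They also leave open how far the value of compound 4 lies past its limit.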